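This account rests on a few compounds, and the source may have more. Where it says the series, first, only, none or still open, it means among the compounds named here.

Results in a functional assay on HeLa cells (Homo sapiens) for antiproliferative activity, read by CCK-8 assay, with a stated time of 48 h (on this read-out higher numbers stand for weaker inhibition and lower numbers for stronger inhibition), for the three measured compounds:
- compound 1 `COc1ccc(/C=C\c2cc(OC)c(OC)c(OC)c2)cc1OCc1ccc(CN2C[C@H](O)C[C@@H]2C(=O)O)cc1` gives > 10000 nM (a limit, not a number)
- compound 2 `COc1ccc(/C=C\c2cc(OC)c(OC)c(OC)c2)cc1OCc1ccc(CN2CC[C@H](C(=O)O)C2)cc1` gives > 10000 nM (a limit, not a number)
- compound 3 `COc1ccc(/C=C\c2cc(OC)c(OC)c(OC)c2)cc1OCc1ccc(CN2CC(C(=O)O)C2)cc1` gives 6500 nM (a true number)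

Within the data shown here, compound 3 holds the only true number here. The other two give only the limit of > 10000 nM in this assay, at which 2 of the 3 values shown sit, and nothing more exact.

Compound 4 `COc1ccc(/C=C\c2cc(OC)c(OC)c(OC)c2)cc1OCc1ccc(CNCCN(C)C)cc1` carries (2-(dimethylamino)ethyl)amino in place of 3-carboxyazetidin-1-yl, on a saturated chain carbon bound to an aromatic carbon ((2-(dimethylamino)ethyl)amino in place of 3-carboxyazetidin-1-yl on a saturated chain carbon bound to an aromatic carbon).

Among the measured compounds shown here, two measured steps bear on this change, an at least 1.5-fold lower number from compound 1 to compound 3 (0.18 log units; that floor lies within the scatter) and an at least 1.5-fold lower number from compound 2 to compound 3 (0.18 log units; that floor lies within the scatter), but both only swap one carboxy-bearing ring for another. Neither removes the carboxy group, so they guide the size only weakly. A moderately lower number is nevertheless expected, with the estimated step being a 2.6-fold lower number from compound 3 to compound 4 (0.41 log units; beyond the scatter) in this assay and an uncertain size. For compound 4 the estimate is 2500 nM, with an expected range from 400 nM to 10000 nM as the likely span.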

Compound 4, half-maximal inhibitory concentration: 9400 nM
Estimate against measurement, compound 4: 3.8-fold (0.58 log units) below; the range from low to high includes it.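

In this assay, (2-(dimethylamino)ethyl)amino in place of 3-carboxyazetidin-1-yl gives a 1.4-fold higher number from compound 3 to compound 4 (0.16 log units; within the scatter). This is the first change shown that removes the carboxy group, and the numbers for compound 3 and compound 4 stay within the scatter of each other, so the carboxy group is not needed for the weak activity seen in compound 3. The other two steps, an at least 1.0-fold lower number from compound 2 to compound 4 (0.02 log units; that floor lies within the scatter) and an at least 1.0-fold lower number from compound 1 to compound 4 (0.02 log units; that floor lies within the scatter), are only floors: the limit of > 10000 nM in this assay, at which 2 of the 4 values shown sit.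

As far as these compounds go, it remains open whether a morpholine ring or a methyl ester on this saturated chain carbon would lower the number beyond the scatter.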